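Replacing (methylsulfonyl)methyl with sulfamoyl in compound 1

The source may report more compounds than this note shows. Statements on the series, on what has been measured and on what is new or still open speak of the compounds shown alone.

Measured in a functional assay on HUVEC cells (Homo sapiens) for inhibition; a lower number here means a stronger inhibitor, a higher number a weaker inhibitor:
Compound 1 `CN(c1ccc(NC(=O)Nc2ccccc2)cc1)c1ccnc(Nc2cccc(CS(C)(=O)=O)c2)n1`: 0.2 nM
Compound 2 `CN(c1ccc(NS(=O)(=O)Cc2ccccc2)cc1)c1ccnc(Nc2cccc(CS(C)(=O)=O)c2)n1`: 350 nM

Compound 1 holds the lower of the two numbers. Within the data shown here, the only measured step, a 1800-fold higher number from compound 1 to compound 2 (3.24 log units; beyond the scatter), is large, but it replaces the phenylcarbamoyl group with benzylsulfonyl. Compound 3 `CN(c1ccc(NC(=O)Nc2ccccc2)cc1)c1ccnc(Nc2cccc(S(N)(=O)=O)c2)n1` keeps that phenylcarbamoyl group and instead carries sulfamoyl in place of (methylsulfonyl)methyl on an aromatic carbon. Among the measured compounds shown here, no measured step touches this place, so the data give no direct size for the change. Since compound 1 stands at 0.2 nM, a moderate rise in the number in this assay is expected, and the estimate is a 4.0-fold higher number from compound 1 to compound 3 (0.60 log units; beyond the scatter). For compound 3 the estimated value is 0.8 nM, with an expected range of 0.1 nM to 8 nM.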

Compound 3, half-maximal inhibitory concentration: 2 nM
For compound 3 the middle estimate is 2.5-fold (0.40 log units) below the measured one; the range from low to high includes it.
By their numbers in this assay, from the lowest: compound 1; then compound 3; then compound 2.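

Sulfamoyl in place of (methylsulfonyl)methyl gives a 10-fold higher number from compound 1 to compound 3 (1.00 log units; beyond the scatter) in this assay and is the first measured change at this place on the aromatic ring. Even so, compound 3 remains a low-nanomolar inhibitor at 2 nM and this step is far smaller than a 1800-fold higher number from compound 1 to compound 2 (3.24 log units; beyond the scatter) at the phenylcarbamoyl end, so this position accepts a change more readily among the compounds shown. No supporting evidence accounts for the rise in the number here. On these data alone, it remains open how a carboxylic acid, an amine or a longer chain would fare at this position, and whether sulfamoyl would have a similar effect with benzylsulfonyl at the other end.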